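The compounds below may be only part of what the source reports. "The series", "measured", "known", "first", "only" and "open" are said of these compounds alone.

Compound 1 `O=C(Nc1cccc(Cl)c1)Nc1nnc(Sc2ncnc3scc(-c4ccncc4)c23)s1`: 21000 nM
Compound 2 `O=C(Nc1cccc(C(F)(F)F)c1)Nc1nnc(Sc2ncnc3scc(-c4ccncc4)c23)s1`: 22400 nM
Compound 3 `Cc1ccc(NC(=O)Nc2nnc(Sc3ncnc4scc(-c5ccncc5)c34)s2)cc1Cl`: 23200 nM

In a functional assay on HUVEC cells (Homo sapiens) for antiproliferative activity, read by MTT assay, with a stated time of 48 h (a higher number here means a weaker inhibitor, a lower number a stronger inhibitor), compound 2 stands second highest of three numbers, but the gaps to its neighbours are small: a 1.1-fold higher number from compound 1 to compound 2 (0.03 log units; within the scatter) and a 1.0-fold higher number from compound 2 to compound 3 (0.02 log units; within the scatter), both within the scatter. Compound 4 `COc1cccc(NC(=O)Nc2nnc(Sc3ncnc4scc(-c5ccncc5)c34)s2)c1` is the next compound, unmeasured so far. It differs from compound 2 in one place: methoxy in place of trifluoromethyl on an aromatic carbon. Among the measured compounds shown here, the nearest precedent is the step in which chloro was replaced by trifluoromethyl at the same place, a 1.1-fold higher number from compound 1 to compound 2 (0.03 log units; within the scatter), which changed nothing beyond the scatter, and the exchange of the whole ring, a 1.0-fold higher number from compound 2 to compound 3 (0.02 log units; within the scatter), was likewise flat. The step in this assay from compound 2 to compound 4 is therefore expected to be small, a 1.0-fold lower number from compound 2 to compound 4 (0.01 log units; within the scatter). Compound 4 is estimated at 22000 nM, between 11000 nM and 44000 nM.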

Compound 4, half-maximal inhibitory concentration: 67700 nM
The estimate for compound 4 lay 3.1-fold (0.49 log units) below the measured number; measured number above the stated range.
By their numbers in this assay, from the lowest: compounds 1, 2 and 3 (each within the scatter of the next); then compound 4.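

In this assay, the group at this place on the ring does matter: methoxy in place of trifluoromethyl gives a 3.0-fold higher number from compound 2 to compound 4 (0.48 log units; beyond the scatter) and methoxy in place of chloro gives a 3.2-fold higher number from compound 1 to compound 4 (0.51 log units; beyond the scatter), although chloro and trifluoromethyl could not be told apart. The whole-ring exchange agrees, with a 2.9-fold higher number from compound 3 to compound 4 (0.47 log units; beyond the scatter) for 3-methoxyphenyl in place of 3-chloro-4-methylphenyl. Nothing shown accounts for this step.

As far as these compounds go, it remains open whether an amine or a hydroxy group at this place would track with methoxy or with chloro and trifluoromethyl.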